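Replacing the hydroxy group of compound 1

The source may report more compounds than this note shows. Statements on the series, on what has been measured and on what is new or still open speak of the compounds shown alone.

Values measured in a functional assay on RAW264.7 cells (Mus musculus) for inhibition (on this read-out higher numbers stand for weaker inhibition and lower numbers for stronger inhibition), are as follows:
- Compound 1 (`COc1cc(C(=O)/C=C/c2cc(OC)c(OC)c(OC)c2)ccc1O`) gives 4190 nM
- Compound 2 (`COc1cccc(O)c1C(=O)/C=C/c1ccccc1`) gives 9600 nM

Compound 1 has the lower number of the two, and its gap to compound 2 lies beyond the scatter. Compound 3 (`COc1cccc(C(=O)/C=C/c2cc(OC)c(OC)c(OC)c2)c1`) differs from compound 1 by hydrogen in place of hydroxy on an aromatic carbon. Going by the values given here, no measured pair shows this change, so the expectation rests on little evidence. A modest rise in the number, meaning weaker inhibition, is expected, with no change beyond the scatter also possible. The expected step is a 1.9-fold higher number from compound 1 to compound 3 (0.28 log units; within the scatter) on this estimate. Compound 3 is expected at 8000 nM (estimated range 3000 nM to 22000 nM).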

Compound 3, half-maximal inhibitory concentration: 2880 nM
For compound 3 the middle estimate is 2.8-fold (0.44 log units) above the measured one, and the stated range ends above it.
By their numbers in this assay, from the lowest: compounds 3 and 1 (each within the scatter of the next); then compound 2.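

In this assay, hydrogen in place of hydroxy on this aromatic carbon, ortho to a methoxy group and para to a large group, gives a 1.5-fold lower number from compound 1 to compound 3 (0.16 log units; within the scatter), so this hydroxy group is not needed to keep inhibition at the level of compound 1 in this series. No available evidence accounts for this result.

As far as these compounds go, whether an amine, a carboxylic acid or a longer alkoxy chain at this position would stay within the scatter of compound 1 remains open. Compound 2 differs from compound 1 in more than one place and so gives no reading on this position.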